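A 4-hydroxybut-2-yn-1-yl chain on the shared core

This account rests on a few compounds, and the source may have more. Where it says the series, first, only, none or still open, it means among the compounds named here.

In a functional assay on L1210 cells (Mus musculus) for inhibition (a higher number here means a weaker inhibitor, a lower number a stronger inhibitor), compound 1 `Nc1nc(O)c2ncn(C/C=C\CO)c2n1`, with a 4-hydroxybut-2-en-1-yl group on an aromatic nitrogen, gives 680000 nM. Compound 2 `Nc1nc(O)c2ncn(C=C=CCO)c2n1`, with 4-hydroxybuta-1,2-dien-1-yl at that place, is reported only as a limit, > 350000 nM. Going by the values given here, the one measured step, a step that the limit leaves unreadable from compound 1 to compound 2, therefore offers no size to carry forward. Compound 3 `Nc1nc(O)c2ncn(CC#CCO)c2n1` has yet to be measured. It has the same atoms as compound 2, joined differently, with 4-hydroxybut-2-yn-1-yl in place of 4-hydroxybuta-1,2-dien-1-yl on an aromatic nitrogen. With no readable step to draw on, no shift in a particular direction is expected in this assay. Among the compounds with values here, the only numerical anchor is compound 1 at 680000 nM. Compound 3 is expected to remain a very weak inhibitor in that region, possibly reported as a limit too. The expected step, a step that the limit leaves unreadable from compound 2 to compound 3, is an estimate only. Compound 3 is estimated at 500000 nM, with an expected range from 180000 nM to 1300000 nM.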

Compound 3, half-maximal inhibitory concentration: 210000 nM
The estimate for compound 3 lay 2.4-fold (0.38 log units) above the measured number; the measured number falls inside the stated range.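

In this assay, going by these compounds alone, the 4-hydroxybut-2-yn-1-yl chain gives the first readable step at this place on an aromatic nitrogen, a 3.2-fold lower number from compound 1 to compound 3 (0.51 log units; beyond the scatter), so the change from the 4-hydroxybut-2-en-1-yl chain does move the number here, though only modestly, and compound 3 still sits at 210000 nM. Against the 4-hydroxybuta-1,2-dien-1-yl chain, the same chain shows an at least 1.6-fold lower number from compound 2 to compound 3 (0.22 log units; that floor lies within the scatter), so this step has only a floor, and that floor does not by itself separate the two chains. Compound 2 stands only as a limit, and the step to it from compound 1 cannot be read: the limit of > 350000 nM in this assay, at which 1 of the 3 values shown sits.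

The compounds shown leave open where the 4-hydroxybuta-1,2-dien-1-yl chain truly stands among the three, and whether a fully saturated 4-hydroxybutyl chain would continue or reverse the shift seen with compound 3. They also leave open what a longer chain would do at this place, or an amine or a carboxylic acid in place of the hydroxyl at the end of the chain.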